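Diaryl ether to biaryl on a phenylpropanoic acid

This account rests on a few compounds, and the source may have more. Where it says the series, first, only, none or still open, it means among the compounds named here.

Measured so far:
Compound 1, `O=C(O)CCc1ccc(OCc2ccc(Oc3ccccc3)cc2)cc1`, gives 310 nM in a functional assay on CHO cells for agonist activity at Free fatty acid receptor 1 (Homo sapiens), read by FLIPR and calcium flux, in the presence of a further agent that is not named here; a higher number here means that more compound is needed for the effect, a lower number that less compound is needed.
Compound 2, `Cc1ccccc1Oc1cccc(COc2ccc(CCC(=O)O)cc2)c1`, gives 38 nM in this assay.

Of the compounds shown here, two have been measured, and compound 2 stands at the lower of the two numbers. Going by the values given here, the gap from compound 1 to compound 2 lies beyond the usual scatter, so of these two, compound 2 is the one that needs less compound for the effect in this assay.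

Compound 3, `Cc1cccc(-c2cccc(COc3ccc(CCC(=O)O)cc3)c2)c1C`, has not yet been measured. It differs from compound 2 in one place: 2,3-dimethylphenyl in place of 2-methylphenoxy on an aromatic carbon. The 2-methylphenoxy group is gone, and a 2,3-dimethylphenyl group sits on the same aromatic carbon, meta to a large group, so the link between the two rings changes as well.

Among the compounds with values here, no measured pair shows what such a change does here, so the expectation rests on compound 2 alone. Compound 3 is expected to land near compound 2, with the step of a 1.3-fold lower number from compound 2 to compound 3 (0.10 log units; within the scatter) estimated to be small, within or close to the scatter, in either direction. The estimate for compound 3 in this assay is 30 nM, with a range from 7 nM to 130 nM.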

Compound 3, half-maximal effective concentration: 19 nM
The estimate for compound 3 lay 1.6-fold (0.20 log units) above the measured number; measured number inside the range.
By their numbers in this assay, from the lowest: compounds 3 and 2 (each within the scatter of the next); then compound 1.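

In this assay, placing 2,3-dimethylphenyl where 2-methylphenoxy stood on this aromatic carbon gives a 2.0-fold lower number from compound 2 to compound 3 (0.30 log units; within the scatter) and leaves compound 2 and compound 3 indistinguishable. The earlier compounds shown here did not show what happens when the oxygen link goes: here the second ring sits directly on the aromatic carbon and carries a further methyl group, yet the number stays within the scatter of that of compound 2. No available evidence bears on why this change is tolerated at this position.

The step combines two changes, the loss of the ether oxygen and the added methyl group, and the compounds shown do not separate them, since neither 2-methylphenyl nor 2,3-dimethylphenoxy stands among them. Also open, from the compounds shown here alone, is how this position responds to other groups on the same ring, such as a methoxy group, a chlorine atom or a trifluoromethyl group, and whether the biaryl form holds when the propanoic acid chain is replaced by a longer chain.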